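This account rests on a few compounds, and the source may have more. Where it says the series, first, only, none or still open, it means among the compounds named here.

Working notes on the aziridine urea series.

Compound 3 `N#CC1CN1C(=O)Nc1ccccc1` is the unsubstituted member of the set. Among the measured compounds shown here, in a functional assay on A-375 cells (Homo sapiens) for inhibition (a lower number here means a stronger inhibitor, a higher number a weaker inhibitor), compound 3 gives 11000 nM, the highest of the three numbers measured so far. Compound 1 `CCOC(=O)c1ccc(NC(=O)N2CC2C#N)cc1`, which carries an ethoxycarbonyl group on an aromatic carbon, gives 5800 nM in this assay, and compound 2 `N#CC1CN1C(=O)Nc1ccc([N+](=O)[O-])cc1`, which carries a nitro group on an aromatic carbon, gives 3900 nM. The step from the ester to the bare ring is a 1.9-fold higher number from compound 1 to compound 3 (0.28 log units; within the scatter), and the step from the nitro compound to the bare ring is a 2.8-fold higher number from compound 2 to compound 3 (0.45 log units; beyond the scatter); between the two substituted compounds the step is a 1.5-fold lower number from compound 1 to compound 2 (0.17 log units; within the scatter).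

Compound 4 `N#CC1CN1C(=O)Nc1ccc(C(F)(F)F)cc1` is not yet measured. It differs from compound 3 by trifluoromethyl in place of hydrogen on an aromatic carbon. For the measured compounds named here, the steps that bear on this change are the two that remove a substituent from an aromatic carbon, since the change to compound 4 puts a substituent back onto an aromatic carbon; both steps point toward higher numbers on removal, one within the scatter and one modestly beyond it. Compound 4 is therefore expected to land on the side of compounds 1 and 2 rather than compound 3, with the expected step of a 2.2-fold lower number from compound 3 to compound 4 (0.34 log units; beyond the scatter). The estimate for compound 4 in this assay is 5000 nM, with a range from 2000 nM to 14000 nM.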

Compound 4, half-maximal inhibitory concentration: 11800 nM
Estimate against measurement, compound 4: 2.4-fold (0.37 log units) below; the measured number falls inside the stated range.
By their numbers in this assay, from the lowest: compounds 2, 1, 3 and 4 (each within the scatter of the next, the first and the last beyond it).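

In this assay, trifluoromethyl in place of hydrogen on the aromatic carbon para to a group of 8 heavy atoms gives a 1.1-fold higher number from compound 3 to compound 4 (0.03 log units; within the scatter), so among the compounds shown, putting a substituent at this position does not by itself move the number away from that of the unsubstituted ring. Among the compounds shown here, the replacement of one substituent by another now matters here, with trifluoromethyl in place of nitro giving a 3.0-fold higher number from compound 2 to compound 4 (0.48 log units; beyond the scatter) and trifluoromethyl in place of ethoxycarbonyl giving a 2.0-fold higher number from compound 1 to compound 4 (0.31 log units; beyond the scatter), both modest steps; nitro remains the only group with a step from hydrogen that is beyond the scatter, while ethoxycarbonyl and trifluoromethyl both stay within it. No measurement is available that accounts for the different results of these groups at this position.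

Still open, on these data alone, is whether an amine, a carboxylic acid or a methoxy group on this carbon would stay with hydrogen and trifluoromethyl or move the number further than nitro does. The compounds shown also leave open whether nitro or trifluoromethyl on another aromatic carbon of the ring would give the same steps.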